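Methoxy added to the hydroxyphenyl thiosemicarbazone

The compounds below may be only part of what the source reports. "The series", "measured", "known", "first", "only" and "open" are said of these compounds alone.

Compound 1 `CC1=CC[C@H](C(C)(C)NC(=S)N/N=C/c2ccc(O)cc2)CC1` gives > 100000 nM in a functional assay on UACC-62 cells (Homo sapiens) for inhibition, read by sulforhodamine B assay, with a stated time of 48 h (a higher number here means a weaker inhibitor of growth, a lower number a stronger inhibitor of growth), which is a limit of this assay rather than a number.
Compound 2 `CC1=CC[C@H](C(C)(C)NC(=S)N/N=C/c2cccc(Cl)c2)CC1` gives 39800 nM in this assay.

Compound 1 thus stands at the weak end, where the limit of > 100000 nM in this assay, at which 1 of the 2 values shown sits, marks its position. Compound 3 `COc1cc(/C=N/NC(=S)NC(C)(C)[C@H]2CC=C(C)CC2)ccc1O` differs from compound 1 by methoxy in place of hydrogen on an aromatic carbon. For the measured compounds named here, no measured step touches this change; the only step known, an at least 2.5-fold lower number from compound 1 to compound 2 (0.40 log units; beyond the scatter), swaps the whole aryl group and says little about an added methoxy. Compound 3 is therefore expected to stay near compound 1, with a number no higher from compound 1 to compound 3 (the limit leaves the size open) as the expected step. The estimate for compound 3 is 100000 nM, within 40000 nM to 200000 nM.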

Compound 3, concentration for total growth inhibition: 42300 nM
For compound 3 the middle estimate is 2.4-fold (0.37 log units) above the measured one; measured number inside the range.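

In this assay the aryl group need not be swapped as a whole to move the read-out: methoxy ortho to a hydroxy group, with that hydroxy group kept, gives an at least 2.3-fold lower number from compound 1 to compound 3 (0.37 log units; beyond the scatter). This position on the ring therefore tolerates an added group and yields a number rather than a limit. From the compounds shown here alone, the full size of the step stays open because the starting point is only a limit: the limit of > 100000 nM in this assay, at which 1 of the 3 values shown sits.

Going by these compounds, whether ethoxy or an amine at this position would give a similar step remains open, as does whether the gain depends on the hydroxy group.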